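A few compounds are considered here, and "the series" means these few. Any claim that something is new, unique, unknown or untested is made for them only; others in the source may bear on it.

Three amides on the shared core have numbers in a functional assay on HepG2 cells (Homo sapiens) for inhibition, read by MTT assay; a lower number here means a stronger inhibitor of growth, a higher number a weaker inhibitor of growth. Compound 1 (`COc1cc2oc(-c3cccc(NC(=O)c4ccc(Br)cc4)c3)cc(=O)c2c(OC)c1OC`) gives 8850 nM, compound 2 (`COc1cc2oc(-c3cccc(NC(=O)c4ccc(Cl)cc4)c3)cc(=O)c2c(OC)c1OC`) gives 21300 nM and compound 3 (`COc1cc2oc(-c3cccc(NC(=O)c4cccc(C#N)c4)c3)cc(=O)c2c(OC)c1OC`) gives 11900 nM. Compound 3 cannot be separated from either of the other two, as a 1.3-fold higher number from compound 1 to compound 3 (0.13 log units; within the scatter) and a 1.8-fold lower number from compound 2 to compound 3 (0.25 log units; within the scatter) show. Only a 2.4-fold higher number from compound 1 to compound 2 (0.38 log units; beyond the scatter), chloro in place of bromo on an aromatic carbon, clears the scatter, and only modestly.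

Compound 4 (`COc1cc2oc(-c3cccc(NC(=O)c4ccc(C)cc4)c3)cc(=O)c2c(OC)c1OC`) has not yet been measured. The change to it is 4-methylphenyl in place of 3-cyanophenyl on a carbonyl carbon. In words, this is 4-methylphenyl in place of 3-cyanophenyl on a carbonyl carbon. Among the measured compounds shown here, no measured compound carries the 4-methylphenyl group, so no step tests this replacement directly. The nearest evidence is the two replacements at the same carbonyl carbon, a 1.3-fold higher number from compound 1 to compound 3 (0.13 log units; within the scatter) and a 1.8-fold lower number from compound 2 to compound 3 (0.25 log units; within the scatter), together with a 2.4-fold higher number from compound 1 to compound 2 (0.38 log units; beyond the scatter), the largest step in the set. On that evidence, a step of only small size is expected, with no clear direction. The expected change is a 1.2-fold higher number from compound 3 to compound 4 (0.07 log units; within the scatter), which would not clear the scatter. Compound 4 is estimated at 14000 nM, with an expected range of 6500 nM to 30000 nM.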

Compound 4, concentration for 50% growth inhibition: 9750 nM
The estimate for compound 4 lay 1.4-fold (0.16 log units) above the measured number, and the stated range covers the measured number.
By their numbers in this assay, from the lowest: compounds 1, 4, 3 and 2 (each within the scatter of the next, the first and the last beyond it).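

In this assay, methyl in place of bromo on the aromatic carbon cannot be told apart from no change (a 1.1-fold higher number from compound 1 to compound 4 (0.04 log units; within the scatter)), whereas methyl in place of chloro clears the scatter, though only modestly (a 2.2-fold lower number from compound 2 to compound 4 (0.34 log units; beyond the scatter)). Among the compounds shown here, compound 2 is therefore separated from two compounds rather than one, yet it stays within the scatter of compound 3, so the halogen exchange and the methyl exchange point to compound 2 as the only compound that goes against an otherwise flat set of numbers. On the carbonyl carbon whose other neighbour is the amide-type nitrogen, 4-methylphenyl also cannot be separated from 3-cyanophenyl (a 1.2-fold lower number from compound 3 to compound 4 (0.09 log units; within the scatter)), even though the exchange removes the triple bond and the hydrogen-bond acceptor counted on 3-cyanophenyl, and nothing available accounts for the size of any of these steps.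

On these data alone, whether this flat picture extends to an amine or a carboxylic acid on the same aromatic ring remains open. So does the outcome with an unsubstituted phenyl or with a longer chain in place of methyl.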